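Exchanging a naphthalene ketone for an ethyl ester

The source may report more compounds than this note shows. Statements on the series, on what has been measured and on what is new or still open speak of the compounds shown alone.

Compound 1, `CC1(C)S[C@@H]2/C(=C\C(=O)c3ccc4ccccc4c3)C(=O)N2[C@H]1C(=O)OC(c1ccccc1)c1ccccc1`, gives 19500 nM in a functional assay on OE19 cells (Homo sapiens) for cytotoxicity, read by MTT assay, with a stated time of 48 h (a higher number here means a weaker inhibitor, a lower number a stronger inhibitor), the lowest of the two numbers measured; compound 2, `CC1(C)[C@H](C(=O)OC(c2ccccc2)c2ccccc2)N2C(=O)/C(=C/C(=O)c3ccccc3)[C@H]2S1(=O)=O`, gives 53100 nM, a difference beyond the scatter. Compound 3, `CCOC(=O)/C=C1/C(=O)N2[C@@H]1SC(C)(C)[C@@H]2C(=O)OC(c1ccccc1)c1ccccc1`, is not yet measured. It differs from compound 1 by ethoxy in place of naphthalen-2-yl on a carbonyl carbon. For the measured compounds named here, no measured pair in this set shows that exchange, so the expectation rests on the size of the group lost alone. Compound 3 is expected to give a higher number, a step of a 2.1-fold higher number from compound 1 to compound 3 (0.31 log units; beyond the scatter), with an estimate of 40000 nM between 12000 nM and 130000 nM.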

Compound 3, half-maximal inhibitory concentration: 11200 nM
Compound 3: middle estimate off by 3.6-fold (0.55 log units), on the high side, and the stated range ends above it.
By their numbers in this assay, from the lowest: compounds 3 and 1 (each within the scatter of the next); then compound 2.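

In this assay the exchange of naphthalen-2-yl for ethoxy on this carbonyl carbon gives a 1.7-fold lower number from compound 1 to compound 3 (0.24 log units; within the scatter) and so leaves the two compounds indistinguishable. The two aromatic rings of naphthalen-2-yl are therefore not needed at this place to keep this level of cytotoxicity, and an ester serves as well as the ketone. Nothing measured here gives a reason for this result. Still open, on these data alone, is whether a longer chain in place of ethoxy would shift the number, and whether an amide or a carboxylic acid at this carbonyl carbon would.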